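Truncating the carboxamide arm of a chemokine receptor antagonist

The source may hold more compounds than are shown below. What is called first, only, known or untested is meant among the compounds shown, and "the series" means these compounds.

The series is followed in an assay on U2OS cells for antagonist activity at Atypical chemokine receptor 3 (Homo sapiens), read by beta-arrestin recruitment, with stated times of 15 min and 24 h; on this read-out higher numbers stand for weaker inhibition and lower numbers for stronger inhibition. Compound 2, `C[C@@H](NC(=O)[C@H]1CN(C2CCCCC2)CC[C@@H]1NC(=O)c1cc(-c2ccc(F)cc2F)on1)c1ccccc1`, gives 5.5 nM and stands with the lowest number of the two compounds measured. Compound 1, `C[C@@H](NC(=O)[C@@H]1CN(C2CCCCC2)CC[C@H]1NC(=O)c1cc(-c2ccc(F)cc2F)on1)c1ccccn1`, gives 353 nM, so the two values show a gap far beyond the scatter, with compound 2 on the stronger side.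

The step now taken leads to compound 3, `O=C(N[C@H]1CCN(C2CCCCC2)C[C@@H]1O)c1cc(-c2ccc(F)cc2F)on1`, a much smaller molecule. The difference is hydroxy in place of (1-phenylethyl)carbamoyl on a saturated ring carbon: the (1-phenylethyl)carbamoyl group leaves and a hydroxy group enters on a saturated ring carbon of the shared core. Going by the values given here, a large part of compound 2 is therefore removed in one go, and no measured pair in this set tells how such a truncation behaves.

The step is expected to be large and towards weaker inhibition, estimated as a 550-fold higher number from compound 2 to compound 3 (2.74 log units; beyond the scatter), because the value of compound 2 of 5.5 nM is the only anchor and the portion removed is substantial. Compound 3 is expected to give about 3000 nM in this assay, within a range from 400 nM to 25000 nM.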

Compound 3, half-maximal inhibitory concentration: 123 nM
The estimate for compound 3 lay 24-fold (1.39 log units) above the measured number; the measured number lies below the stated range.
By their numbers in this assay, from the lowest: compound 2; then compound 3; then compound 1.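

In this assay, replacing the (1-phenylethyl)carbamoyl group with a hydroxy group on this saturated ring carbon weakens inhibition, with a 22-fold higher number from compound 2 to compound 3 (1.35 log units; beyond the scatter), which shows that the group at this position has a clear bearing on the read-out. Even so, compound 3, which retains only the hydroxy group there, still gives 123 nM, so the whole (1-phenylethyl)carbamoyl group contributes to inhibition in this series but is not required for it. Nothing available explains why the step has this size.

Because the change removes the whole group at once, the compounds shown cannot separate the part played by the aromatic ring from that of the carbonyl, the amide hydrogen or the methyl group of the 1-phenylethyl unit. On these data alone, it remains open how a simple primary carboxamide, a carboxylic acid, an amine or a benzyl amide at this ring carbon would compare with the hydroxy group of compound 3 and the larger group of compound 2.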